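Dropping the chloro from a chromone thioether

The source may hold more compounds than are shown below. What is called first, only, known or untested is meant among the compounds shown, and "the series" means these compounds.

Compound 1 `Cc1nnc(SCc2cc(=O)c3ccccc3o2)o1` and compound 2 `Cc1nnc(SCc2coc3ccc(Cl)cc3c2=O)o1` were measured in a functional assay on HeLa cells (Homo sapiens) for cytotoxicity, read by MTT assay, with a stated time of 72 h; on this read-out higher numbers stand for weaker inhibition and lower numbers for stronger inhibition. In this assay compound 1 gives > 25000 nM, which is a limit of the assay and not a number. Compound 2 gives 3200 nM, the only number shown. The other value, that of compound 1, is a limit (the limit of > 25000 nM in this assay, at which 1 of the 2 values shown sits). Compound 3 `Cc1nnc(SCc2coc3ccccc3c2=O)o1` is not yet measured. It differs from compound 2 by hydrogen in place of chloro on an aromatic carbon. Among the compounds with values here, no measured pair shows a comparable step. The step is expected to be a modest weakening, a 2.5-fold higher number from compound 2 to compound 3 (0.40 log units; beyond the scatter), beyond the scatter. Compound 3 is therefore estimated at 8000 nM, within 2500 nM to 25000 nM.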

Compound 3, half-maximal inhibitory concentration: 1400 nM
Compound 3: middle estimate off by 5.7-fold (0.76 log units), on the high side, and the stated range ends above it.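

In this assay the exchange of chloro for hydrogen gives a 2.3-fold lower number from compound 2 to compound 3 (0.36 log units; beyond the scatter) so the chloro on this aromatic carbon, meta to a fused ring and para to a fused ring, is not required for the cytotoxicity seen here, and the unsubstituted compound reads as the stronger of the pair. Within the data shown here, this is the first step read at this position, and it runs in the direction of hydrogen over chloro. Nothing among the data given accounts for this change. On these data alone, whether a fluoro, a methoxy or an amine on the same carbon would read higher or lower than hydrogen remains open. So does whether this step would hold on any cell line other than HeLa.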